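The source may report more compounds than this note shows. Statements on the series, on what has been measured and on what is new or still open speak of the compounds shown alone.

Measured so far in a functional assay on A549 cells (Homo sapiens) for inhibition, read by sulforhodamine B assay, with a stated time of 48 h; on this read-out higher numbers stand for weaker inhibition and lower numbers for stronger inhibition:

compound 1 `CO[C@@H]1CC=C2NN(c3cc(Cl)cc(Cl)c3)C(=O)C[C@]2(C)O1` — 17500 nM
compound 2 `CO[C@@H]1CC=C2NN(c3cc(F)cc(Cl)c3)C(=O)C[C@]2(c2ccccc2)O1` — 14100 nM
compound 3 `CO[C@@H]1CC=C2NN(c3ccc(Cl)cc3)C(=O)C[C@]2(C)O1` — 25500 nM

Compound 3 gives the highest of the three numbers in this assay, yet its gap to compound 1 and its gap to compound 2 both lie within the usual scatter of the method, so the three values cannot be ranked against each other on this evidence. Within the data shown here, no pair among the three differs in one place only, so no single-point step is available as a guide.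

Compound 4 `CO[C@@H]1CC=C2NN(c3cccnc3)C(=O)C[C@]2(C)O1` is the next point. It differs from compound 3 in one place: pyridin-3-yl in place of 4-chlorophenyl on an amide-type nitrogen in a ring. Among the measured compounds shown here, no measured pair reports what such a swap does on this core, so the expectation rests only on the narrow spread of the three values seen so far. A step of modest size is expected from compound 3 to compound 4 in this assay, a 1.2-fold higher number from compound 3 to compound 4 (0.07 log units; within the scatter), with the direction uncertain and a value near the present cluster most likely. Compound 4 is therefore estimated at 30000 nM, in a range from 12000 nM to 80000 nM.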

Compound 4, half-maximal inhibitory concentration: 14400 nM
The estimate for compound 4 lay 2.1-fold (0.32 log units) above the measured number; the measured number falls inside the stated range.
By their numbers in this assay, from the lowest: compounds 2, 4, 1 and 3 (each within the scatter of the next).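

In this assay, among these compounds, the first single-place step reads a 1.8-fold lower number from compound 3 to compound 4 (0.25 log units; within the scatter) for pyridin-3-yl in place of 4-chlorophenyl on an amide-type nitrogen in a ring. The swap puts a ring nitrogen and a hydrogen-bond acceptor where the carbon-only aromatic ring and its chlorine stood, and the step does not separate the two compounds, so the 4-chlorophenyl group is not shown to be needed at this position for a value in this range. No measurement at hand speaks to what lies behind this step.

From the compounds shown here alone, whether pyridin-4-yl, or a non-aromatic group such as cyclohexyl, would give a step beyond the scatter at this position remains open. So does the effect of an amine or a carboxylic acid on the aromatic ring there.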